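From thiophen-3-yl to 1-benzofuran-2-yl on a shared core

The compounds below may be only part of what the source reports. "The series", "measured", "known", "first", "only" and "open" are said of these compounds alone.

Of the compounds shown here, two built on a shared core have been tested so far, and only one of them gave an exact number. In an ADME assay on BJ cells (Homo sapiens), read by MTT assay, with a stated time of 72 h (a higher number here means a weaker inhibitor, a lower number a stronger inhibitor), compound 1 `COc1ncnc2c1c(-c1cc3ccccc3o1)cn2[C@@H]1O[C@H](CO)[C@@H](O)[C@H]1O`, which carries 1-benzofuran-2-yl, gives 22400 nM. Compound 2 `CNc1ncnc2c1c(-c1ccsc1)cn2[C@@H]1O[C@H](CO)[C@@H](O)[C@H]1O`, which carries thiophen-3-yl, gives > 100000 nM in this assay. That reading is a limit of the assay and not a number.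

Compound 3 `CNc1ncnc2c1c(-c1cc3ccccc3o1)cn2[C@@H]1O[C@H](CO)[C@@H](O)[C@H]1O` keeps the rest of compound 2 and makes a single change, with 1-benzofuran-2-yl in place of thiophen-3-yl on an aromatic carbon. Going by the values given here, no pair of tested compounds shows this change alone. The expectation therefore leans on compound 1, which carries the entering group and gives 22400 nM, although it differs from compound 3 elsewhere on the core. In this assay a move toward stronger inhibition is expected, beyond the scatter, though its size is uncertain. The expected step is an at least 3.3-fold lower number from compound 2 to compound 3 (0.52 log units; beyond the scatter). For compound 3 the estimate is 30000 nM, with an expected range of 9000 nM to 100000 nM.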

Compound 3, half-maximal inhibitory concentration: 75600 nM
Beside the measured number, compound 3's estimate is 2.5-fold (0.40 log units) below it; the range from low to high includes it.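

Going by these compounds alone, compound 3 gives the first direct reading of 1-benzofuran-2-yl in place of thiophen-3-yl on this aromatic carbon: in this assay the change gives an at least 1.3-fold lower number from compound 2 to compound 3 (0.12 log units; that floor lies within the scatter). The true step may be larger, but its size cannot be fixed, because the value of compound 2 is a limit of the assay and not a number: the limit of > 100000 nM in this assay, at which 1 of the 3 values shown sits.

Within the data shown here, the second pair adds a reading at a different place, with 1-benzofuran-2-yl held fixed: methylamino in place of methoxy on an aromatic carbon gives a 3.4-fold higher number from compound 1 to compound 3 (0.53 log units; beyond the scatter), a move toward weaker inhibition and the only step here that is clearly beyond the scatter.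

It remains open how a carboxylic acid or a simple amine would read on the carbon that bears 1-benzofuran-2-yl, since only two groups are shown there and one of them gives no exact number. Also open, on these data alone, is whether an ethylamino group or a longer chain in place of methylamino would move the number further in the same direction as the step from methoxy.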